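Removing the hydroxy group from a four-membered lactam

The source may report more compounds than this note shows. Statements on the series, on what has been measured and on what is new or still open speak of the compounds shown alone.

Measured compounds:
compound 1 `CCOc1ccc(C2C(Oc3ccccc3)C(=O)N2c2cc(OC)c(OC)c(OC)c2)cc1` 388 nM
compound 2 `CCSc1ccc(C2CC(=O)N2c2cc(OC)c(OC)c(OC)c2)cc1` 311 nM
compound 3 `CCOc1ccc(C2C(O)C(=O)N2c2cc(OC)c(OC)c(OC)c2)cc1` 15 nM

In a functional assay on HT-29 cells (Homo sapiens) for inhibition, read by sulforhodamine B assay, with a stated time of 72 h (on this read-out higher numbers stand for weaker inhibition and lower numbers for stronger inhibition), compound 3 gives the lowest number of the three. Compound 4 `CCOc1ccc(C2CC(=O)N2c2cc(OC)c(OC)c(OC)c2)cc1` differs from it by hydrogen in place of hydroxy on a saturated ring carbon. Within the data shown here, only one measured step touches this position: a 26-fold lower number from compound 1 to compound 3 (1.41 log units; beyond the scatter), which shows that what sits there changes the number a great deal. Compound 2, which carries nothing at this position but has a different group on the phenyl ring, gives 311 nM, a much higher number than compound 3. A clearly higher number for compound 4 is therefore expected, a 13-fold higher number from compound 3 to compound 4 (1.12 log units; beyond the scatter). Compound 4 is estimated at 200 nM, with a likely range from 50 nM to 800 nM.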

Compound 4, half-maximal inhibitory concentration: 65 nM
Compound 4: the middle estimate sits 3.1-fold (0.49 log units) above what was measured, within the range that was stated.
By their numbers in this assay, from the lowest: compound 3; then compound 4; then compounds 2 and 1 (each within the scatter of the next).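

In this assay, the hydroxy group on this saturated ring carbon proves helpful but not essential, with a 4.3-fold higher number from compound 3 to compound 4 (0.64 log units; beyond the scatter), while hydrogen there still beats phenoxy, with a 6.0-fold lower number from compound 1 to compound 4 (0.78 log units; beyond the scatter). The bare position alone therefore does not account for the high number of compound 2, since the change from ethylsulfanyl to ethoxy on the aromatic carbon gives a 4.8-fold lower number from compound 2 to compound 4 (0.68 log units; beyond the scatter). Nothing available explains these differences.

The compounds shown leave open how a small methoxy group or an amine on this ring carbon would compare with hydroxy and hydrogen.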